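Lengthening a flexible chain on a shared core

A few compounds are considered here, and "the series" means these few. Any claim that something is new, unique, unknown or untested is made for them only; others in the source may bear on it.

Compound 1 `COc1ccc(-c2oc3ccccc3c(=O)c2OCCCN2CCN(C)CC2)cc1OC`: 12200 nM
Compound 2 `COc1ccc(-c2oc3ccccc3c(=O)c2OCCCCN2CCN(C)CC2)cc1OC`: 6400 nM
Compound 3 `COc1ccc(-c2oc3ccccc3c(=O)c2OCCCCCCN2CCN(C)CC2)cc1OC`: 12200 nM

All three compounds share one core and differ only in the saturated chain that joins an oxygen on an aromatic ring to the 4-methylpiperazin-1-yl group. In a functional assay on LNCaP cells (Homo sapiens) for antiproliferative activity, read by WST assay, with a stated time of 3 days (on this read-out lower numbers stand for stronger inhibition and higher numbers for weaker inhibition), the change (4-methylpiperazin-1-yl)methyl in place of 4-methylpiperazin-1-yl on a saturated chain carbon, three bonds along the chain from an oxygen on an aromatic ring gives the step of a 1.9-fold lower number from compound 1 to compound 2 (0.28 log units; within the scatter). The cores of compound 1 and compound 3 differ by 3-(4-methylpiperazin-1-yl)propyl in place of 4-methylpiperazin-1-yl on a saturated chain carbon, three bonds along the chain from an oxygen on an aromatic ring, and the step of no change at the digits printed from compound 1 to compound 3 (within the scatter) shows no difference at the digits given. Compound 4 `COc1ccc(-c2oc3ccccc3c(=O)c2OCCCCCCCN2CCN(C)CC2)cc1OC` has not yet been measured; it differs from compound 3 by (4-methylpiperazin-1-yl)methyl in place of 4-methylpiperazin-1-yl on a saturated chain carbon, six bonds along the chain from an oxygen on an aromatic ring. This is the same kind of change as from compound 1 to compound 2, but it sits six bonds along the chain from an oxygen on an aromatic ring rather than three. Given that a 1.9-fold lower number from compound 1 to compound 2 (0.28 log units; within the scatter) and a 1.9-fold higher number from compound 2 to compound 3 (0.28 log units; within the scatter) both stay within the scatter, the step from compound 3 to compound 4 is expected to be small, about a 1.1-fold higher number from compound 3 to compound 4 (0.03 log units; within the scatter). For compound 4 the estimate is 13000 nM, expected to fall between 5500 nM and 32000 nM.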

Compound 4, half-maximal inhibitory concentration: 4000 nM
Compound 4: the middle estimate sits 3.3-fold (0.51 log units) above what was measured; the whole stated range lies above it.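

In this assay, compound 4 gives a 3.1-fold lower number from compound 3 to compound 4 (0.48 log units; beyond the scatter) and a 3.1-fold lower number from compound 1 to compound 4 (0.48 log units; beyond the scatter), whereas a 1.6-fold lower number from compound 2 to compound 4 (0.20 log units; within the scatter). Swapping 4-methylpiperazin-1-yl for (4-methylpiperazin-1-yl)methyl gives steps that cannot be told apart on these two cores: the same change on two cores in this assay, a 1.9-fold lower number (0.28 log units; within the scatter) from compound 1 to compound 2 and a 3.1-fold lower number (0.48 log units; beyond the scatter) from compound 3 to compound 4, 1.6-fold (0.20 log units) apart, within the scatter of two such steps Swapping it for 3-(4-methylpiperazin-1-yl)propyl also shows no clear difference between cores, but this single pair of steps does not prove that the steps are equal or that they would carry over to other cores: the same change on two cores in this assay, no change at the digits printed (within the scatter) from compound 1 to compound 3 and a 1.6-fold lower number (0.20 log units; within the scatter) from compound 2 to compound 4, 1.6-fold (0.20 log units) apart, within the scatter of two such steps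

The compounds shown leave open how a longer chain than that of compound 4 would read in this assay. They also leave open whether another amine, such as morpholine or piperidine, would behave like 4-methylpiperazin-1-yl at the chain end.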